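Replacing the 4-phenylphenyl group of compound 3

This account rests on a few compounds, and the source may have more. Where it says the series, first, only, none or still open, it means among the compounds named here.

Compound 1 `CCN(CC)c1ccc(N2C(=O)CSC2c2cccc(C(=O)NCCCCc3ccccc3)c2)cc1` gives > 1000 nM (a limit)
Compound 2 `O=C(NCCCCc1ccccc1)c1cc(F)cc(C2SCC(=O)N2c2ccccn2)c1` gives 14.2 nM
Compound 3 `O=C(NCCCCc1ccccc1)c1cccc(C2SCC(=O)N2c2ccc(-c3ccccc3)cc2)c1` gives > 1000 nM (a limit)

All three results come from a functional assay on HOS-TE85 cells (Homo sapiens) for inhibition, read by CCK-8 assay, with a stated time of 72 h; on this read-out lower numbers stand for stronger inhibition and higher numbers for weaker inhibition. Compound 3 stands at > 1000 nM, which is a limit and not a number. The picture so far is marked by the limit of > 1000 nM in this assay, at which 2 of the 3 values shown sit.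

Compound 4 `COc1c(F)cccc1N1C(=O)CSC1c1cccc(C(=O)NCCCCc2ccccc2)c1` carries 3-fluoro-2-methoxyphenyl in place of 4-phenylphenyl on an amide-type nitrogen in a ring. Going by the values given here, the only measured step that touches compound 3 is a step that the two limits leave unreadable from compound 1 to compound 3, so it offers no size to carry over to this change.

Among the compounds with values here, the one real number belongs to compound 2 , which gives 14.2 nM with a different group on that nitrogen and a further change elsewhere. That value shows that this family can reach strong inhibition in this assay, while compound 1 and compound 3 go against any general trend. A move toward stronger inhibition is therefore expected, with wide uncertainty and a real chance that the result stays at the limit. The expected change is an at least 4.0-fold lower number from compound 3 to compound 4 (0.60 log units; beyond the scatter). For compound 4 the estimated value is 250 nM, with an expected range from 25 nM to 2500 nM.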

Compound 4, half-maximal inhibitory concentration: 26.2 nM
Estimate against measurement, compound 4: 9.5-fold (0.98 log units) above, within the range that was stated.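

In this assay, the group on the amide-type nitrogen of the five-membered ring has a large say in the outcome: 3-fluoro-2-methoxyphenyl in place of 4-phenylphenyl gives an at least 38-fold lower number from compound 3 to compound 4 (1.58 log units; beyond the scatter). Going by these compounds alone, the same group in place of 4-(diethylamino)phenyl gives an at least 38-fold lower number from compound 1 to compound 4 (1.58 log units; beyond the scatter), so compound 4 provides the first measured value on the core shared by compound 1 and compound 3. Both steps give only a minimum size, because compound 1 and compound 3 each stand at a limit and not at a number: the limit of > 1000 nM in this assay, at which 2 of the 4 values shown sit.

The change swaps two aromatic rings for one and brings in a fluorine and a methoxy together, so the compounds shown cannot tell which of these differences matters, or whether all of them do. A plain 2-methoxyphenyl or 3-fluorophenyl on that nitrogen would pull the two new groups apart, while a simple unsubstituted phenyl would show what the single ring does on its own.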